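The compounds below may be only part of what the source reports. "The series", "measured", "known", "first", "only" and "open" are said of these compounds alone.

Compound 1 `[O-]/[N+](=C\c1cn(-c2ccccc2)nn1)c1ccccc1`: in a functional assay on MDA-MB-231 cells (Homo sapiens) for inhibition, read by MTT assay, with a stated time of 24 h (on this read-out lower numbers stand for stronger inhibition and higher numbers for weaker inhibition), compound 1 reaches only the limit > 100000 nM.
Compound 2 `[O-]/[N+](=C\c1cn(-c2ccc(F)cc2)nn1)c1ccccc1`: compound 2 gives 9800 nM.
Compound 3 `[O-]/[N+](=C\c1cn(-c2ccccc2)nn1)Cc1ccccc1`: compound 3 reaches only the limit > 100000 nM.

Compound 3 therefore stands at the limit of this assay, a limit shared by two of the three values shown (the limit of > 100000 nM in this assay, at which 2 of the 3 values shown sit). Compound 4 `[O-]/[N+](=C\c1cn(-c2ccc(F)cc2)nn1)Cc1ccccc1` differs from compound 3 by fluoro in place of hydrogen on an aromatic carbon. Within the data shown here, the one measured step of the same kind, an at least 10-fold lower number from compound 1 to compound 2 (1.00 log units; beyond the scatter), went from that same limit to a real number. The other measured step, a step that the two limits leave unreadable from compound 1 to compound 3, cannot be read because both ends are limits. A downward step of comparable size is thus expected in this assay, with the caution that the limit on compound 3 hides its true starting point. Compound 4 is expected at 15000 nM, between 4000 nM and 100000 nM, an estimated step of an at least 6.6-fold lower number from compound 3 to compound 4 (0.82 log units; beyond the scatter).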

Compound 4, half-maximal inhibitory concentration: > 100000 nM
Compound 4: only a limit was reported; the forecaster's own chance of this, stated with the estimate: 40%; middle value at least 6.6-fold (0.82 log units) from the limit.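

With the 4-fluorophenyl group kept in place, benzyl in place of phenyl on the double-bonded nitrogen gives an at least 10-fold higher number from compound 2 to compound 4 (1.00 log units; beyond the scatter). So the fluoro group yields a real number only in compound 2, and that number does not carry over to the benzyl compound. The step between compound 3 and compound 4 cannot be read, because both of its ends are limits: the limit of > 100000 nM in this assay, at which 3 of the 4 values shown sit.

Going by these compounds, whether fluoro changes anything at all in the benzyl compounds stays open. So does whether a chloro or methoxy group in place of fluoro, or a phenethyl group in place of benzyl, would give a real number in this assay.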